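The compounds below may be only part of what the source reports. "The series", "measured", "known", "first", "only" and "open" are said of these compounds alone.

Compound 1 `CCOC(=O)c1cnc(N2CCN(Cc3ccccc3C#N)CC2)nc1Oc1c(C)cc(-c2ccc(C#N)cc2)cc1C` — in an ADME assay on MT4 cells (Homo sapiens) for cytotoxicity, read by MTT assay, with a stated time of 4 days (on this read-out lower numbers stand for higher toxicity in this test and higher numbers for lower toxicity in this test), compound 1 gives > 125000 nM, which is a limit of the test rather than a number.
Compound 2 `CCOC(=O)c1cnc(N2CCN(Cc3cccc([N+](=O)[O-])c3)CC2)nc1Oc1c(C)cc(-c2ccc(C#N)cc2)cc1C` — in this assay compound 2 gives > 125000 nM, again only a limit.

Within the data shown here, compound 2 therefore stands at the edge of what this test can report, and the one other measured value sits at the same place (the limit of > 125000 nM in this assay, at which 2 of the 2 values shown sit). Among the measured compounds shown here, the only measured step, from compound 1 to compound 2, reads a step that the two limits leave unreadable from compound 1 to compound 2, so its size cannot be told. Compound 3 `CCOC(=O)c1cnc(N2CCN(Cc3ccc(S(C)(=O)=O)cc3)CC2)nc1Oc1c(C)cc(-c2ccc(C#N)cc2)cc1C` differs from compound 2 by 4-(methylsulfonyl)phenyl in place of 3-nitrophenyl on a saturated chain carbon bound to an amine nitrogen in a ring. For the measured compounds named here, since no measured step has a readable size, no change beyond the usual scatter is expected in this assay in either direction. Compound 3 is estimated at 150000 nM, within 80000 nM to 300000 nM, most likely reported again only as a limit. The expected step is a step that the limit leaves unreadable from compound 2 to compound 3.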

Compound 3, half-maximal cytotoxic concentration: > 125000 nM
Compound 3 ended at the assay's limit; the forecaster's own chance of this, stated with the estimate: 80%; the middle value is on the limit's open side.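

No step can be read among compound 1, compound 2 and compound 3 in this assay, as each result is only a limit: the limit of > 125000 nM in this assay, at which 3 of the 3 values shown sit.

The compounds shown leave open whether exchanging these groups changes toxicity at all, and at what concentration any of the three would harm the cells.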